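This account rests on a few compounds, and the source may have more. Where it says the series, first, only, none or still open, it means among the compounds named here.

In a physicochemical assay for solubility, read by spectrophotometry, in phosphate buffer, measured as kinetic solubility, with a stated time of 18 h, at pH 7.4 (a lower number here means a less soluble compound, a higher number a more soluble compound), compound 1 `O=C(O)COc1cc(Cl)c(C(=O)Nc2cccc(-c3nc4ccccc4s3)c2)cc1[N+](=O)[O-]` gives 6700 nM and stands highest of the two numbers available, while compound 2 `Cc1ccc(-c2nc3ccccc3s2)cc1NC(=O)c1cc([N+](=O)[O-])c(N2CCC(C(=O)O)CC2)cc1Cl` gives 590 nM at a gap beyond the scatter. Compound 3 `O=C(Nc1cccc(-c2nc3ccccc3s2)c1)c1cc([N+](=O)[O-])c(O)cc1Cl` is still unmeasured. The change hydrogen in place of carboxymethyl on an oxygen on an aromatic ring from compound 1 puts hydrogen in place of carboxymethyl on an oxygen on an aromatic ring. Going by the values given here, no measured pair shows this change, so the expectation is loose: a modest fall little beyond the scatter, with a 2.2-fold lower number from compound 1 to compound 3 (0.35 log units; beyond the scatter) as the expected step in this assay here. For compound 3 the estimate is 3000 nM with an expected range from 700 nM to 12000 nM when it is tested.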

Compound 3, solubility: 2200 nM
The estimate for compound 3 lay 1.4-fold (0.13 log units) above the measured number, within the range that was stated.
By their numbers in this assay, from the lowest: compound 2; then compound 3; then compound 1.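

In this assay, going by these compounds alone, the pair gives the first direct reading at this position: hydrogen in place of carboxymethyl on an oxygen on an aromatic ring produces a 3.0-fold lower number from compound 1 to compound 3 (0.48 log units; beyond the scatter), a modest step. The change therefore registers here, though this rests on a single pair on one core. No measurement available bears on what lies behind the step. The compounds shown leave open how a methyl or a longer chain ending in a carboxylic acid on this oxygen would read. They also leave open whether an amine in its place would read differently.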